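Trimming the benzyl on selenium down to methyl

A few compounds are considered here, and "the series" means these few. Any claim that something is new, unique, unknown or untested is made for them only; others in the source may bear on it.

Compound 1 `CS/C(=N\C(=O)c1csc([N+](=O)[O-])c1)NC(=O)c1csc([N+](=O)[O-])c1` and compound 2 `O=C(/N=C(/NC(=O)c1csc([N+](=O)[O-])c1)[Se]Cc1ccccc1)c1csc([N+](=O)[O-])c1` share a core in which two aromatic carbonyl groups flank a carbon double-bonded to nitrogen. In a functional assay on HT-29 cells (Homo sapiens) for cytotoxicity, read by MTT assay, with a stated time of 72 h (a lower number here means that less compound is tolerated, a higher number that more compound is tolerated), compound 1 reaches only the limit of > 100000 nM. In this assay compound 2 likewise reaches only the limit of > 100000 nM. The step that the two limits leave unreadable from compound 1 to compound 2 cannot be sized, since both readings sit at a limit (the limit of > 100000 nM in this assay, at which 2 of the 2 values shown sit). Compound 3 `C[Se]/C(=N\C(=O)c1csc([N+](=O)[O-])c1)NC(=O)c1csc([N+](=O)[O-])c1` differs from compound 2 by hydrogen in place of phenyl on a saturated chain carbon bound to a selenium atom, which is the same as turning benzyl into methyl. Going by the values given here, no measured step reads a number; what stands is the limit of > 100000 nM in this assay, at which 2 of the 2 values shown sit. Compound 3 is therefore expected to remain at that limit, so that the step that the limit leaves unreadable from compound 2 to compound 3 is expected to be none beyond the scatter. The estimate for compound 3 in this assay is 150000 nM, with a range from 50000 nM to 500000 nM.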

Compound 3, concentration lethal to 50% of the cells: > 100000 nM
Compound 3: a limit, no number; the forecaster's own chance of this, stated with the estimate: 80%; the middle value does not contradict the limit.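

Going by these compounds alone, no step among compound 1, compound 2 and compound 3 can be read, as all three readings are limits and not numbers: the limit of > 100000 nM in this assay, at which 3 of the 3 values shown sit.

The compounds shown leave open at what concentration any of them would reach half-lethal effect in this assay, and whether exchanging sulfur for selenium or benzyl for methyl changes it.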